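This account rests on a few compounds, and the source may have more. Where it says the series, first, only, none or still open, it means among the compounds named here.

Working notes on the urea series in an ADME assay on the whole organism with Oryza sativa as the target, tested at 10 uM; on this read-out lower numbers stand for a stronger effect and higher numbers for a weaker effect at the one concentration tested.

Compound 2 `C[C@H](NC(=O)Nc1ccccc1F)c1ccccc1` gives 65% in this assay. Compound 1 `C[C@H](NC(=O)Nc1ccccc1C(F)(F)F)c1ccccc1` differs by trifluoromethyl in place of fluoro on an aromatic carbon and gives 97% in this assay, a step of a number 32 percentage points higher from compound 2 to compound 1 (beyond the scatter). Compound 3 `C[C@@H](NC(=O)Nc1cc(F)ccc1F)c1ccccc1` gives 92% in this assay; the difference between the cores of compound 2 and compound 3 is not broken down here.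

Compound 4 `C[C@@H](NC(=O)Nc1cc(C(F)(F)F)ccc1F)c1ccccc1` is not yet measured; it differs from compound 3 by trifluoromethyl in place of fluoro on an aromatic carbon. This is the same kind of change as from compound 2 to compound 1, but the place differs: there the new group sat ortho to a large group, here it sits meta to a large group and para to a fluoro group.

In this assay the step for compound 4 is expected to be a number 6 percentage points higher from compound 3 to compound 4 (within the scatter), smaller than the earlier one, because compound 3 already gives 92% and the read-out has little room above it. Compound 4 is expected to give 98% in this assay, between 90% and 104%.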

Compound 4, a percentage reported as activity, at one concentration (the size of the read-out at that concentration, not a potency): 60%
For compound 4 the middle estimate is 38 percentage points above the measured one; measured number below the stated range.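

In this assay the new step reads a number 32 percentage points lower from compound 3 to compound 4 (beyond the scatter), and trifluoromethyl in place of fluoro on an aromatic carbon therefore keeps neither its direction nor its effect from one core to the other: the same change on two cores in this assay, a number 32 percentage points higher (beyond the scatter) from compound 2 to compound 1 and a number 32 percentage points lower (beyond the scatter) from compound 3 to compound 4, 64 percentage points apart, beyond the scatter of two such steps

The two steps differ both in the core, including its configuration, and in the place of the change, and these compounds cannot separate the two. Two steps also give no rule for the rest of the series.

Open, from the compounds shown here alone, is whether a chloro group, a methoxy group or a nitrile at these places would follow either step. Also open, going by these compounds, is how an amine or a carboxylic acid on the aromatic ring would read in this assay.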